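The source may report more compounds than this note shows. Statements on the series, on what has been measured and on what is new or still open speak of the compounds shown alone.

In a functional assay on A-375 cells (Homo sapiens) for antiproliferative activity, read by MTT assay, with a stated time of 24 h (a lower number here means a stronger inhibitor, a higher number a weaker inhibitor), three compounds sharing one core have been measured. Compound 1 `C#CCOc1ccc2c(=O)c(-c3cc(OC)c(OC)cc3OC)coc2c1`, with a propargyl group on an oxygen on an aromatic ring, gives 3680 nM. Compound 2 `COc1cccc(C(=O)Oc2ccc3c(=O)c(-c4cc(OC)c(OC)cc4OC)coc3c2)c1`, with a (3-methoxyphenyl)carbonyl group in that place, reads > 10000 nM, which is a limit of the assay and not a number. Among the measured compounds shown here, compound 3 `COc1cc(OC)c(-c2coc3cc(OCc4cccc(Cl)c4)ccc3c2=O)cc1OC`, with a 3-chlorobenzyl group there, gives 980 nM, the lowest actual number so far.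

Compound 4 `COc1cc(OC)c(-c2coc3cc(OCc4ccc(C(F)(F)F)cc4)ccc3c2=O)cc1OC` exchanges 3-chlorobenzyl for 4-(trifluoromethyl)benzyl: 4-(trifluoromethyl)phenyl in place of 3-chlorophenyl on a saturated chain carbon bound to an oxygen on an aromatic ring. For the measured compounds named here, two measured steps bear on this position: a 3.8-fold lower number from compound 1 to compound 3 (0.57 log units; beyond the scatter) and an at least 10-fold lower number from compound 2 to compound 3 (1.00 log units; beyond the scatter). Both replace the whole group, however, while compound 4 keeps the benzyl group and alters only what sits on its ring. Going by the values given here, no measured pair shows such a change, so no step beyond the scatter is expected in this assay, and the range must stay wide. The expected step is a 1.2-fold higher number from compound 3 to compound 4 (0.09 log units; within the scatter). For compound 4, the estimated value is 1200 nM, with an expected range of 400 nM to 4000 nM.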

Compound 4, half-maximal inhibitory concentration: 2280 nM
Compound 4: the middle estimate sits 1.9-fold (0.28 log units) below what was measured; measured number inside the range.
By their numbers in this assay, from the lowest: compound 3; then compounds 4 and 1 (each within the scatter of the next). At a limit, above all of these: compound 2.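

The ring of the benzyl group is not a neutral passenger at this position: changing only what it carries gives a 2.3-fold higher number from compound 3 to compound 4 (0.37 log units; beyond the scatter). A benzyl group in place of propargyl therefore does not by itself bring a clear change, since 3-chlorobenzyl gave one, while 4-(trifluoromethyl)benzyl gives only a 1.6-fold lower number from compound 1 to compound 4 (0.21 log units; within the scatter). Replacing the (3-methoxyphenyl)carbonyl group still gives an at least 4.3-fold lower number from compound 2 to compound 4 (0.64 log units; beyond the scatter), where the starting value is a limit of the assay and not a number.

Because 3-chlorobenzyl and 4-(trifluoromethyl)benzyl differ in both the group on the ring and its place, the compounds shown cannot tell which of the two produced the step. On these data alone, how a benzyl ring carrying an amine or a carboxylic acid would behave also remains open.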